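Hepatocyte clearance notes on a small hydroxamate series

The compounds below may be only part of what the source reports. "The series", "measured", "known", "first", "only" and "open" are said of these compounds alone.

Measured in an ADME assay on cells (Hepatocyte, Homo sapiens) for pharmacokinetics, read by LC-MS, with a stated time of 90 min, tested at 1 uM; on this read-out higher numbers stand for fast clearance and lower numbers for slow clearance:
compound 1 `C[C@@H](Nc1c(NCCCCCC(=O)NO)c(=O)c1=O)c1ccccc1` gives < 5 uL/min, a limit of the assay.
compound 2 `Cc1cccc([C@@H](C)Nc2c(NCCCCCC(=O)NO)c(=O)c2=O)c1` gives < 5 uL/min, a limit of the assay.
compound 3 `CC(CCCCC(=O)NO)Nc1c(Nc2ccccc2)c(=O)c1=O` gives < 5 uL/min, a limit of the assay.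

Compound 2 differs from compound 1 by methyl in place of hydrogen on an aromatic carbon. The step that the two limits leave unreadable from compound 1 to compound 2 cannot be read, as both of its values sit at the limit of < 5 uL/min in this assay, at which 3 of the 3 values shown sit. Compound 4 `Cc1ccc(Nc2c(NC(C)CCCCC(=O)NO)c(=O)c2=O)cc1` differs from compound 3 by methyl in place of hydrogen on an aromatic carbon. The difference between the cores of compound 1 and compound 3 is not broken down here. The change to compound 4 is of the same kind as that to compound 2, but the place differs: meta to a large group in compound 2, para to a large group in compound 4. Compound 4 is expected to give 3 uL/min, with a range from 1 uL/min to 7 uL/min, because the limit of < 5 uL/min in this assay, at which 3 of the 3 values shown sit, holds every measured value of the series. The expected step that the limit leaves unreadable from compound 3 to compound 4 rests on the limit of < 5 uL/min in this assay, at which 3 of the 3 values shown sit, alone. Most likely compound 4 will again be reported only as a limit.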

Compound 4, intrinsic clearance in a liver preparation (reported as CLH), per the amount of preparation that the assay uses: < 6.5 uL/min
Compound 4 gave a limit, no number (the forecaster's own chance of this, stated with the estimate: 80%); the middle value lies beyond the limit too.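

Compound 3 and compound 4 both stand only as limits in this assay, and the step between them cannot be read. The compounds shown leave open how fast any of them is cleared and whether an added methyl changes that clearance.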